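Cyanophenyl change from compound 3 to compound 4

This account rests on a few compounds, and the source may have more. Where it says the series, first, only, none or still open, it means among the compounds named here.

Measured values in a functional assay on SH-SY5Y cells (Homo sapiens) for antiproliferative activity, read by MTT assay, with a stated time of 72 h (on this read-out lower numbers stand for stronger inhibition and higher numbers for weaker inhibition), for the series so far:
compound 1 `COc1cc2c(Nc3cccc(C#N)c3)ncnc2cc1OCCCN1CCCC1` gives 10600 nM
compound 2 `COc1cc2c(Nc3cccc(C#N)c3)ncnc2cc1OCCCN1CCCCC1` gives 11200 nM
compound 3 `CCN1CCN(CCCOc2cc3ncnc(Nc4cccc(C#N)c4)c3cc2OC)CC1` gives 6270 nM

Compound 3 stands level with the other two measured compounds: the steps are a 1.7-fold lower number from compound 1 to compound 3 (0.23 log units; within the scatter) and a 1.8-fold lower number from compound 2 to compound 3 (0.25 log units; within the scatter) and both stay inside the usual scatter. The step of a 1.1-fold higher number from compound 1 to compound 2 (0.02 log units; within the scatter) also stays inside it.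

Compound 4 `CCN1CCN(CCCOc2cc3ncnc(Nc4ccccc4C#N)c3cc2OC)CC1` has the same atoms as compound 3, joined differently, with 2-cyanophenyl in place of 3-cyanophenyl on a nitrogen on an aromatic ring as the counted difference. In words, it carries 2-cyanophenyl in place of 3-cyanophenyl on a nitrogen on an aromatic ring.

All three measured steps exchange the pyrrolidin-1-yl, piperidin-1-yl and 4-ethylpiperazin-1-yl groups on the chain. None of them alters the cyanophenyl group, so they bear on this change only indirectly, by showing a flat series. Within the data shown here, the data hold no measured step for this change, and nothing fixes a direction in this assay for it. No step beyond the scatter is therefore expected, and the estimate starts from compound 3 at 6270 nM as its anchor. The expected move is a 1.2-fold higher number from compound 3 to compound 4 (0.08 log units; within the scatter) and it remains an estimate only. For compound 4 the expected value is 7500 nM with an estimated range from 3300 nM to 18000 nM as the likely span.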

Compound 4, half-maximal inhibitory concentration: 12600 nM
Estimate against measurement, compound 4: 1.7-fold (0.23 log units) below, within the range that was stated.
By their numbers in this assay, from the lowest: compounds 3, 1, 2 and 4 (each within the scatter of the next).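

Among these compounds, this is the first step that touches the cyanophenyl group rather than the amine at the end of the chain. In this assay, 2-cyanophenyl in place of 3-cyanophenyl on a nitrogen on an aromatic ring gives a 2.0-fold higher number from compound 3 to compound 4 (0.30 log units; within the scatter), so moving the nitrile around this ring, with the 4-ethylpiperazin-1-yl chain end held fixed, does not separate the two isomers beyond the scatter, and like the three chain-end exchanges this step leaves the series flat. No measured information on these compounds accounts for this result in either direction.

The compounds shown leave open whether 4-cyanophenyl, or a plain phenyl with no nitrile at all, would stay level with 3-cyanophenyl and 2-cyanophenyl in this read-out, and so whether the nitrile itself matters here. They also leave open whether 2-cyanophenyl would give a similar result on the pyrrolidin-1-yl and piperidin-1-yl chains, or with a different chain end such as morpholin-4-yl, since this exchange is seen only once, on a single chain end.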